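Ring swap at the oxazole: pyridine to pyrimidine

This account rests on a few compounds, and the source may have more. Where it says the series, first, only, none or still open, it means among the compounds named here.

Measured so far:
Compound 1, `Nc1cccc(-c2cnc(C(=O)CCCCCCc3ccccc3)o2)c1`: 19 nM in an assay (Rattus norvegicus) for inhibition of Fatty-acid amide hydrolase 1 (Homo sapiens); on this read-out higher numbers stand for weaker inhibition and lower numbers for stronger inhibition
Compound 2, `COc1ccnc(-c2cnc(C(=O)CCCCCCc3ccccc3)o2)c1`: 0.8 nM in this assay

Of the two numbers recorded, compound 2 holds the lowest, and its nearest neighbour is compound 1 with a 24-fold lower number from compound 1 to compound 2 (1.38 log units; beyond the scatter). Compound 3, `O=C(CCCCCCc1ccccc1)c1ncc(-c2ccncn2)o1`, is not yet measured. It differs from compound 2 in one place: pyrimidin-4-yl in place of 4-methoxypyridin-2-yl on an aromatic carbon. Within the data shown here, only one measured step touches this part of the molecule, the change from compound 1 to compound 2, which gave a 24-fold lower number from compound 1 to compound 2 (1.38 log units; beyond the scatter); it shows that this six-membered ring matters greatly, but it involves a different pair of rings, so no step bears directly on the present change. Compound 3 keeps a six-membered aromatic ring with ring nitrogen at this position and loses the methoxy group, so compound 3 is expected to stay close to compound 2, with at most a modest rise in number. The expected step is a 2.5-fold higher number from compound 2 to compound 3 (0.40 log units; beyond the scatter). Compound 3 is thus estimated at 2 nM, with a range from 0.5 nM to 8 nM.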

Compound 3, inhibition constant: 2.3 nM
Estimate against measurement, compound 3: 1.2-fold (0.06 log units) below; the range from low to high includes it.
By their numbers in this assay, from the lowest: compound 2; then compound 3; then compound 1.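

Dropping the methoxy group and taking a ring with 2 hetero atoms costs only part of the potency in this assay (a 2.9-fold higher number from compound 2 to compound 3 (0.46 log units; beyond the scatter)), so the very low number of compound 2 does not require the 4-methoxypyridin-2-yl group itself. Compound 3 still keeps most of the advantage over the aniline-type ring (an 8.3-fold lower number from compound 1 to compound 3 (0.92 log units; beyond the scatter)), which shows that a second ring type with ring nitrogen, and without methoxy, also beats 3-aminophenyl at this carbon of the oxazole. Nothing measured explains the rise or the retained potency.

Going by these compounds, the swap changes the ring and removes the methoxy group in one move, so their separate shares stay unknown. An unsubstituted pyridine ring, or a pyrimidine ring carrying a methoxy group, would separate them.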